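The source may hold more compounds than are shown below. What is called first, only, known or untested is meant among the compounds shown, and "the series" means these compounds.

Compound 1 `CC(C)(C)c1ccc(CNCCCNS(=O)(=O)c2cc(C(F)(F)F)cc(C(F)(F)F)c2)cc1`: 2300 nM
Compound 2 `O=S(=O)(NCCCNCc1ccc(-c2ccccc2)cc1)c1cc(C(F)(F)F)cc(C(F)(F)F)c1`: 2400 nM
Compound 3 `COc1cccc(CNCCCNS(=O)(=O)c2cc(C(F)(F)F)cc(C(F)(F)F)c2)c1`: 3400 nM

In a functional assay on MIA PaCa-2 cells (Homo sapiens) for inhibition, read by MTT assay, with a stated time of 72 h (on this read-out higher numbers stand for weaker inhibition of growth and lower numbers for stronger inhibition of growth), compound 3 gives 3400 nM, nominally the highest of the three numbers, yet its gaps to compound 1 and to compound 2 both fall within the scatter, so the three compounds cannot be told apart. Compound 4 `O=S(=O)(NCCCNCc1ccc(Cl)cc1)c1cc(C(F)(F)F)cc(C(F)(F)F)c1` differs from compound 3 in one place: 4-chlorophenyl in place of 3-methoxyphenyl on a saturated chain carbon bound to an amine nitrogen. Going by the values given here, two measured steps bear on this, since each also swaps the group on that same chain carbon: a 1.0-fold higher number from compound 1 to compound 2 (0.02 log units; within the scatter) and a 1.5-fold higher number from compound 1 to compound 3 (0.17 log units; within the scatter). Both stayed within the scatter. The expectation for compound 4 is therefore a step of a 1.2-fold lower number from compound 3 to compound 4 (0.08 log units; within the scatter), that is, no change beyond the scatter. Compound 4 is estimated at 2800 nM, with a range from 1400 nM to 5600 nM.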

Compound 4, concentration for 50% growth inhibition: 2800 nM
For compound 4 middle estimate and measured number coincide at the digits printed; the range from low to high includes it.
By their numbers in this assay, from the lowest: compounds 1, 2, 4 and 3 (each within the scatter of the next).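

In this assay the ring on the saturated chain carbon bound to an amine nitrogen tolerates a plain chloro group: it reads the same as 3-methoxyphenyl (a 1.2-fold lower number from compound 3 to compound 4 (0.08 log units; within the scatter)), as the phenyl it replaces (a 1.2-fold higher number from compound 2 to compound 4 (0.07 log units; within the scatter)) and as the tert-butyl it replaces (a 1.2-fold higher number from compound 1 to compound 4 (0.09 log units; within the scatter)). All four compounds therefore remain indistinguishable, whatever the ring carries among these groups, and nothing measured here offers an explanation. Open, as far as these compounds go, is whether a carboxylic acid or an amine on this ring, or a longer chain, would move the number beyond the scatter.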